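Adding a Second Chloro Group to the Benzoyl Ring

A few compounds are considered here, and "the series" means these few. Any claim that something is new, unique, unknown or untested is made for them only; others in the source may bear on it.

Of the compounds shown here, three of a shared core have numbers so far in a functional assay on SW1573 cells (Homo sapiens) for inhibition, read by sulforhodamine B assay, with a stated time of 48 h; on this read-out higher numbers stand for weaker inhibition of growth and lower numbers for stronger inhibition of growth. Compound 1 `CC(=O)OC/C(=C\c1ccccc1)C(=O)c1ccccc1` gives 4800 nM in this assay. Compound 2 `CC(=O)OC/C(=C\c1ccc(Cl)cc1)C(=O)c1ccccc1` gives 2600 nM, and compound 3 `CC(=O)OC/C(=C\c1ccccc1F)C(=O)c1ccccc1` gives 6100 nM. Compound 2 has the lowest number of the three: the step of a 1.8-fold lower number from compound 1 to compound 2 (0.27 log units; within the scatter) is within the scatter, while the step of a 2.3-fold higher number from compound 2 to compound 3 (0.37 log units; beyond the scatter) lies beyond it, and the step of a 1.3-fold higher number from compound 1 to compound 3 (0.10 log units; within the scatter) is again within the scatter.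

Compound 4 `CC(=O)OC/C(=C\c1ccc(Cl)cc1)C(=O)c1ccc(Cl)cc1` is not yet measured. It differs from compound 2 by one change: chloro in place of hydrogen on an aromatic carbon. Going by the values given here, the only measured step of the same kind is the one from compound 1 to compound 2, where a chloro group entered the other ring; that step, a 1.8-fold lower number from compound 1 to compound 2 (0.27 log units; within the scatter), stayed within the scatter. Nothing measured tells what a chloro group does on the benzoyl ring itself, so the expectation rests on that single step and its small size.

Compound 4 is therefore expected to give a number close to that of compound 2, with a step of a 1.3-fold lower number from compound 2 to compound 4 (0.11 log units; within the scatter) that may well remain within the scatter. The estimate for compound 4 in this assay is 2000 nM, in a range from 800 nM to 5000 nM.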

Compound 4, concentration for 50% growth inhibition: 3400 nM
Beside the measured number, compound 4's estimate is 1.7-fold (0.23 log units) below it; low and high end bracket the measured number.
By their numbers in this assay, from the lowest: compounds 2, 4, 1 and 3 (each within the scatter of the next, the first and the last beyond it).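

In this assay, going by these compounds alone, the first measured chloro group on the benzoyl ring, placed para to a large group, gives a 1.3-fold higher number from compound 2 to compound 4 (0.12 log units; within the scatter), so this position tolerates the change without a step beyond the scatter. The chloro group on the other ring gave a 1.8-fold lower number from compound 1 to compound 2 (0.27 log units; within the scatter), which also lies within the scatter, so among the compounds shown neither ring's chloro step can be told apart from repeat measurement, and compound 2 and compound 4 cannot be ranked against each other. Nothing available bears on why the number behaves this way at this position.

The compounds shown leave open whether a group other than chloro at this same place on the benzoyl ring, such as an amine, a methoxy group or a carboxylic acid, would give a step beyond the scatter. They also leave open whether the chloro step on the benzoyl ring would read the same with hydrogen in place of chloro on the other ring, as in the core of compound 1, and whether a longer chain in place of the acetate would shift the numbers at all.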